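Pyridin-2-yl exchange on compound 2: expected shift

This account rests on a few compounds, and the source may have more. Where it says the series, first, only, none or still open, it means among the compounds named here.

- compound 1 `CC1(C)Oc2ccc(C#N)cc2[C@@H](n2ccccc2=O)[C@@H]1O` gives 300 nM
- compound 2 `CC1(C)Oc2ccc(C#N)cc2[C@@H](Oc2ccccn2)[C@]1(C)O` gives 6000 nM

Going by the values given here, both values come from a functional assay for inhibition, with Sus scrofa as the target (on this read-out higher numbers stand for weaker inhibition and lower numbers for stronger inhibition), and no measured pair differs in one place only. Compound 2 has the higher number of the two, and the gap to compound 1 lies beyond the usual scatter, so compound 2 shows the weaker inhibition of this pair.

Compound 3 `CC1(C)Oc2ccc(C#N)cc2[C@@H](Oc2ccc(=O)[nH]n2)[C@]1(C)O` has not yet been measured. Its difference from compound 2 is a group of 7 heavy atoms (4 carbon, 2 nitrogen, 1 oxygen; one six-membered aromatic ring with 2 hetero atoms) in place of a group of 6 heavy atoms (5 carbon, 1 nitrogen; one six-membered aromatic ring with 1 hetero atom), on an oxygen on a saturated carbon and it sits on an oxygen on a saturated carbon.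

Compound 1 at 300 nM carries a ring carbonyl, as the entering group does, so a move towards lower numbers is expected, although compound 1 also differs from compound 2 elsewhere. This is thin support, resting on a single comparison. The expected change is a 7.5-fold lower number from compound 2 to compound 3 (0.88 log units; beyond the scatter) in the direction of stronger inhibition, a step estimated to lie beyond the scatter.

For compound 3 the estimated value is 800 nM with a range from 150 nM to 5000 nM in this assay.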

Compound 3, half-maximal inhibitory concentration: 6 nM
The estimate for compound 3 lay 130-fold (2.12 log units) above the measured number; measured number outside the range, below it.
By their numbers in this assay, from the lowest: compound 3; then compound 1; then compound 2.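

In this assay, the group on the oxygen on a saturated carbon proves to be a strong determinant of the read-out: replacing pyridin-2-yl with the entering ring, with the rest of compound 2 unchanged, gives a 1000-fold lower number from compound 2 to compound 3 (3.00 log units; beyond the scatter). Going by these compounds alone, this is the first single-place comparison, so the size of a change at this position can now be read directly rather than inferred from compounds that also differ elsewhere. Nothing available explains why the step is so large.

The exchange adds a ring nitrogen, a ring carbonyl and a hydrogen-bond donor together, so the compounds shown do not separate what each of these contributes to the step. They also leave open how the position responds to other groups on the same oxygen, such as a phenyl ring or a carboxylic acid, and whether the entering ring has a comparable effect on the core of compound 1.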